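Replacing thiophen-2-yl with 4-fluorophenyl in compound 3

This account rests on a few compounds, and the source may have more. Where it says the series, first, only, none or still open, it means among the compounds named here.

In a functional assay on HCT-116 cells (Homo sapiens) for antiproliferative activity, with a stated time of 72 h (a higher number here means a weaker inhibitor, a lower number a stronger inhibitor), compound 1 (`Cc1c(CNc2ccc(C(=O)Nc3cc(-c4ccccc4)ccc3N)cc2)cnn1C`) gives 670 nM and compound 2 (`Nc1ccc(-c2ccccc2)cc1NC(=O)c1ccc(CN2CCC3(CCNC3)CC2)cc1`) gives 309 nM. Compound 3 (`Nc1ccc(-c2cccs2)cc1NC(=O)c1ccc(C(=O)N2CCC3(CCCN3)CC2)cc1`) gives 70 nM, the lowest number of the three and beyond the scatter of both others. Compound 4 (`Nc1ccc(-c2ccc(F)cc2)cc1NC(=O)c1ccc(C(=O)N2CCC3(CCCN3)CC2)cc1`) differs from compound 3 in one place, with 4-fluorophenyl in place of thiophen-2-yl on an aromatic carbon. Within the data shown here, the only measured single-place step, a 2.2-fold lower number from compound 1 to compound 2 (0.34 log units; beyond the scatter), concerns a different group and gives no direct measure of this change. Compound 2 and compound 3 differ in more than one place, so the gap between their values cannot be assigned to any one of those differences. The forecast in this assay therefore starts from the value of compound 3, 70 nM, and allows for a small move toward a higher number that may stay within the scatter. The expected step is a 1.7-fold higher number from compound 3 to compound 4 (0.23 log units; within the scatter). For compound 4 the estimated value is 120 nM, with an expected range of 50 nM to 300 nM.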

Compound 4, half-maximal inhibitory concentration: 138 nM
Beside the measured number, compound 4's estimate is 1.2-fold (0.06 log units) below it; low and high end bracket the measured number.
By their numbers in this assay, from the lowest: compounds 3 and 4 (each within the scatter of the next); then compound 2; then compound 1.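

Among these compounds, this is the first step that changes only the aromatic group para to the amino group, and it comes to a 2.0-fold higher number from compound 3 to compound 4 (0.29 log units; within the scatter). In this assay, thiophen-2-yl and 4-fluorophenyl therefore cannot be told apart at this position, even though the change swaps a five-membered aromatic ring holding sulfur for a six-membered aromatic ring of carbon only, with fluorine added. Nothing measured here explains this result.

Still open, going by these compounds, is how a pyridine ring, a furan ring or an aromatic ring bearing a methoxy group would read at this position. So is the part played by the fluorine, as plain phenyl appears only in compound 1 and compound 2, which differ from compound 4 in more than that one place.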